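The source may hold more compounds than are shown below. What is called first, only, known or untested is meant among the compounds shown, and "the series" means these compounds.

Compound 3 `Cc1cc(=O)cc2c3c1[C@H](O)[C@@H]1[C@@H]4OC(=O)[C@](CC2)(C(C)C4O)[C@H]31` gives the lowest number of the two measured in a functional assay on HL-60 cells (Homo sapiens) for inhibition, read by CCK-8 assay, with a stated time of 72 h (a higher number here means a weaker inhibitor, a lower number a stronger inhibitor), at 2200 nM. Compound 2 `Cc1cc(=O)cc2c3c1C[C@@H]1[C@@H]4OC(=O)[C@](C[C@H]2O)(C(C)C4O)[C@H]31` returns 38400 nM in this assay, a gap to compound 3 that lies beyond the scatter. Compound 1 `Cc1cc(=O)cc2c3c1[C@@H](O)[C@H]1[C@@H]3[C@]3(CC2)C(=O)O[C@@H]1CC3C` reaches only a limit of the assay in this assay, > 50000 nM. Compound 4 `Cc1cc(=O)cc2c3c1[C@H](O)[C@H]1[C@@H]3[C@]3(CC2)C(=O)O[C@@H]1CC3C` has not yet been measured. It differs from compound 3 by hydrogen in place of hydroxy on a saturated ring carbon. Going by the values given here, with no measured step of this kind to lean on, and with the single hydroxy-poorer compound 1 sitting at its limit (the limit of > 50000 nM in this assay, at which 1 of the 3 values shown sits), the step is expected to go toward a weaker inhibitor, a 6.8-fold higher number from compound 3 to compound 4 (0.83 log units; beyond the scatter). Compound 4 is therefore estimated at 15000 nM in this assay, within a range from 3000 nM to 60000 nM.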

Compound 4, half-maximal inhibitory concentration: 3500 nM
The estimate for compound 4 lay 4.3-fold (0.63 log units) above the measured number; the measured number falls inside the stated range.
By their numbers in this assay, from the lowest: compounds 3 and 4 (each within the scatter of the next); then compound 2. At a limit, above all of these: compound 1.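

Hydrogen in place of hydroxy on this saturated ring carbon gives a 1.6-fold higher number from compound 3 to compound 4 (0.20 log units; within the scatter), so this hydroxy is not required for the inhibition seen with compound 3. Compound 1 and compound 4 share the same atoms and bonds, yet a single stereocentre at a saturated ring carbon, drawn S in compound 1 and R in compound 4, separates them, with an at least 14-fold lower number from compound 1 to compound 4 (1.15 log units; beyond the scatter). The number for compound 1 is a limit, so that step has no exact size: the limit of > 50000 nM in this assay, at which 1 of the 4 values shown sits.

From the compounds shown here alone, how firmly this step can be read as a change of configuration stays open: the fact that one of compounds 1 and 4 is drawn with a defined configuration and the other without, at the place where they differ Also open is how an amine or a methoxy group on that saturated ring carbon would compare with hydroxy and hydrogen.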